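Aryl Swap on the Pyrazole of a Weak Antiproliferative Series

The source may report more compounds than this note shows. Statements on the series, on what has been measured and on what is new or still open speak of the compounds shown alone.

Compound 1 `COc1cccc(-c2nn(-c3ccccc3)cc2C(Nc2nc3ccccc3s2)c2c(O)ccc3ccccc23)c1`: 24800 nM
Compound 2 `COc1cccc(-c2nn(-c3ccccc3)cc2C(Nc2nc3ccc(Cl)cc3s2)c2c(O)ccc3ccccc23)c1`: 49800 nM

In a functional assay on A549 cells (Homo sapiens) for antiproliferative activity, read by MTT assay, with a stated time of 48 h (on this read-out higher numbers stand for weaker inhibition and lower numbers for stronger inhibition), compound 2 gives 49800 nM, the highest of the two numbers; its nearest neighbour is compound 1, and the step of a 2.0-fold higher number from compound 1 to compound 2 (0.30 log units; within the scatter) stays within the scatter. Compound 3 `Oc1ccc2ccccc2c1C(Nc1nc2ccc(Cl)cc2s1)c1cn(-c2ccccc2)nc1-c1ccc(I)cc1` differs from compound 2 by 4-iodophenyl in place of 3-methoxyphenyl on an aromatic carbon. For the measured compounds named here, no measured step bears on this change; the only one on record concerns a chloro substituent elsewhere and was within the scatter. The step of a 1.1-fold lower number from compound 2 to compound 3 (0.04 log units; within the scatter) is therefore expected to stay within the scatter. Compound 3 is estimated at 45000 nM, within 15000 nM to 135000 nM.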

Compound 3, half-maximal inhibitory concentration: 29000 nM
Estimate against measurement, compound 3: 1.6-fold (0.19 log units) above; measured number inside the range.
By their numbers in this assay, from the lowest: compounds 1, 3 and 2 (each within the scatter of the next).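

In this assay, 4-iodophenyl in place of 3-methoxyphenyl on this aromatic carbon of the five-membered ring gives a 1.7-fold lower number from compound 2 to compound 3 (0.23 log units; within the scatter). For the compounds shown here, this is the first sign that this position tolerates an exchange of aryl groups, with the oxygen gone and iodine present, without a change beyond the scatter. No measurement on hand offers an explanation for this result.

Because both the substituent and its place on the phenyl ring differ, the two cannot be separated. On these data alone, it remains open whether an amine or a carboxylic acid on that phenyl ring would shift the number beyond the scatter.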